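This account rests on a few compounds, and the source may have more. Where it says the series, first, only, none or still open, it means among the compounds named here.

Compound 2 `COc1cc2c(Oc3ccc(NC(=O)c4cn(-c5c(Cl)cccc5Cl)nn4)cc3F)ccnc2cc1OCCCN1CCC(C)CC1` gives 120 nM in a functional assay on MKN-45 cells (Homo sapiens) for cytotoxicity, read by MTT assay, with a stated time of 72 h (on this read-out higher numbers stand for weaker inhibition and lower numbers for stronger inhibition), the lower of the two numbers at hand. Compound 1 `COc1cc2c(Oc3ccc(NC(=O)c4cn(-c5c(C)cccc5C)nn4)cc3F)ccnc2cc1OCCCN1CCC(C)CC1` differs from it only in the group on an aromatic nitrogen, and compound 1 gives 4310 nM. The step of a 36-fold lower number from compound 1 to compound 2 (1.56 log units; beyond the scatter) shows that this group can move the number a long way. Compound 3 `COc1cc2c(Oc3ccc(NC(=O)c4cn(-c5ccc(F)c(F)c5)nn4)cc3F)ccnc2cc1OCCCN1CCC(C)CC1` alters the same group once more: 3,4-difluorophenyl in place of 2,6-dichlorophenyl on an aromatic nitrogen. For the measured compounds named here, no measured step compares the new group with either earlier one, so the single step already seen is the only guide, and it says that the number depends strongly on this group without telling which way the new group will go. Compound 3 is therefore expected to land between the two measured values, which means an estimated step of a 3.8-fold higher number from compound 2 to compound 3 (0.57 log units; beyond the scatter) as the central guess. For compound 3 the estimate in this assay is 450 nM, within a range from 80 nM to 2500 nM.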

Compound 3, half-maximal inhibitory concentration: 1290 nM
Estimate against measurement, compound 3: 2.9-fold (0.46 log units) below; measured number inside the range.
By their numbers in this assay, from the lowest: compound 2; then compound 3; then compound 1.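

In this assay, two rings that each carry two halogens do not behave alike: 3,4-difluorophenyl in place of 2,6-dichlorophenyl brings an 11-fold higher number from compound 2 to compound 3 (1.03 log units; beyond the scatter) even though both groups have the same count of heavy atoms and neither has a hydrogen-bond donor or acceptor. Set against 2,6-dimethylphenyl, the same group gives a 3.3-fold lower number from compound 1 to compound 3 (0.52 log units; beyond the scatter) and so takes the middle rank, which means this position gives three clearly separated numbers rather than one large jump. Nothing available here bears on why the three groups fall in this order.

Compound 3 changes both the halogen and its place on the ring, so these compounds cannot show which of the two changes matters. Also open, as far as these compounds go, is where 2,6-difluorophenyl or unsubstituted phenyl would fall in this order.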